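Hydroxy to acetoxy on the shared core

A few compounds are considered here, and "the series" means these few. Any claim that something is new, unique, unknown or untested is made for them only; others in the source may bear on it.

Compound 2 `COc1cc(C2=C(c3cc(C)c(OC)c(C)c3)C(O)CC2=O)cc(OC)c1OC` is one of three members assessed in an ADME assay on DU-145 cells (Homo sapiens) for cytotoxicity, read by MTT assay, with a stated time of 72 h; a lower number here means a stronger inhibitor, a higher number a weaker inhibitor. Compound 2 gives only a limit there, > 100 ug/mL. Compound 1 `COc1ccc(C2=C(c3cc(OC)c(OC)c(OC)c3)CC(O)C2=O)cc1[N+](=O)[O-]` also reaches only a limit in this assay, > 100 ug/mL. In this assay, among the compounds with values here, compound 3 `COc1ccc(C2=C(c3cc(OC)c(OC)c(OC)c3)C(=O)CC2O)cc1` gives 18.7 ug/mL, the single numeric value in the set. Where compound 2 stands is therefore (the limit of > 100 ug/mL in this assay, at which 2 of the 3 values shown sit); no step between measured compounds is available to anchor any change. Compound 4 `COc1cc(C2=C(c3cc(C)c(OC)c(C)c3)C(OC(C)=O)CC2=O)cc(OC)c1OC` is not yet measured. It differs from compound 2 by acetyl in place of hydrogen on an oxygen on a saturated carbon. Within the data shown here, with no measured step to lean on, the hydroxy to acetoxy change is expected to give no move beyond the scatter, a step that the limit leaves unreadable from compound 2 to compound 4. Compound 4 is accordingly estimated at 120 ug/mL, within 45 ug/mL to 320 ug/mL, with a real chance that only a limit is again reported.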

Compound 4, half-maximal inhibitory concentration: > 100 ug/mL
Compound 4 was reported as a limit; the forecaster's own chance of this, stated with the estimate: 60%; the middle value is on the limit's open side.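

Compound 2 and compound 4 are both reported only as limits, and no step can be read between them. The compounds shown leave open whether the hydroxy to acetoxy change moves the half-maximal inhibitory concentration at all.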